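A few compounds are considered here, and "the series" means these few. Any claim that something is new, unique, unknown or untested is made for them only; others in the source may bear on it.

Of the compounds shown here, three built on a shared core have been measured in an assay on Sf21 cells for inhibition of high affinity nerve growth factor receptor (Homo sapiens), read by HTRF, with a stated time of 30 min, in the presence of a further agent that is not named here; a lower number here means a stronger inhibitor, a higher number a weaker inhibitor. Compound 1 `CC1(C)c2[nH]nc(NC(=O)c3ccccc3)c2CN1Cc1ccccc1` gives 1240 nM. Compound 2 `CC1(C)c2[nH]nc(NC(=O)c3ccccc3)c2CN1Cc1cccc(C#N)c1` gives 980 nM, which is the second highest of the three numbers, and compound 3 `CC1(C)c2[nH]nc(NC(=O)c3ccccc3)c2CN1Cc1ccc(F)c(F)c1` gives 680 nM. The step of a 1.3-fold lower number from compound 1 to compound 2 (0.10 log units; within the scatter) and the step of a 1.4-fold lower number from compound 2 to compound 3 (0.16 log units; within the scatter) both stay within the scatter, as does a 1.8-fold lower number from compound 1 to compound 3 (0.26 log units; within the scatter), so the three variations on the benzyl group do not separate from one another on these numbers.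

Compound 4 `Cc1ccc(F)c(CN2Cc3c(NC(=O)c4ccccc4)n[nH]c3C2(C)C)c1` has not yet been measured. Its change from compound 2 is 2-fluoro-5-methylphenyl in place of 3-cyanophenyl on a saturated chain carbon bound to an amine nitrogen in a ring. For the measured compounds named here, the steps that bear on this are the two earlier changes to the same aromatic ring, a 1.3-fold lower number from compound 1 to compound 2 (0.10 log units; within the scatter) and a 1.4-fold lower number from compound 2 to compound 3 (0.16 log units; within the scatter), both small. No step beyond the scatter is therefore expected in this assay, in either direction. Compound 4 is expected to give about 850 nM, with a range from 400 nM to 1800 nM. The expected step is a 1.2-fold lower number from compound 2 to compound 4 (0.06 log units; within the scatter), within the scatter.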

Compound 4, half-maximal inhibitory concentration: 880 nM
Compound 4: middle estimate off by 1.0-fold (0.02 log units), on the low side; low and high end bracket the measured number.
By their numbers in this assay, from the lowest: compounds 3, 4, 2 and 1 (each within the scatter of the next).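

In this assay, the change from 3-cyanobenzyl to 2-fluoro-5-methylbenzyl gives a 1.1-fold lower number from compound 2 to compound 4 (0.05 log units; within the scatter), so losing the nitrile and its hydrogen-bond acceptor leaves no readable mark on the number. The other new steps, a 1.3-fold higher number from compound 3 to compound 4 (0.11 log units; within the scatter) and a 1.4-fold lower number from compound 1 to compound 4 (0.15 log units; within the scatter), show that 2-fluoro-5-methylphenyl on this saturated chain carbon bound to an amine nitrogen in a ring also does not separate from 3,4-difluorophenyl or from plain phenyl. Nothing available here bears on why these groups read alike.

On these data alone, all four compounds carry a benzyl group at this position, so it remains open whether an aminoethyl chain, a carboxylic acid or a longer chain ending in phenyl would move the number beyond the scatter. The shared core and the amide are the same throughout, which leaves the effect of any change there unknown.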